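Adding two chlorines to the imine-bearing phenyl ring

The compounds below may be only part of what the source reports. "The series", "measured", "known", "first", "only" and "open" are said of these compounds alone.

Measured so far:
compound 1 `Cc1c(/N=C/c2ccccc2Cl)c(=O)n(-c2ccccc2)n1C`: 851000000 nM
compound 2 `Cc1c(/N=C/c2ccccc2)c(=O)n(-c2ccccc2)n1C`: 589000000 nM

In a functional assay on HCT-116 cells (Homo sapiens) for cytotoxicity, read by MTT assay, with a stated time of 72 h (a higher number here means a weaker inhibitor, a lower number a stronger inhibitor), compound 2 gives the lowest of the two numbers, though the gap to compound 1 is small: a 1.4-fold lower number from compound 1 to compound 2 (0.16 log units; within the scatter). Compound 3 `Cc1c(/N=C/c2ccc(Cl)cc2Cl)c(=O)n(-c2ccccc2)n1C` differs from compound 2 by 2,4-dichlorophenyl in place of phenyl on a carbon with a double bond to nitrogen. For the measured compounds named here, the only step that bears on this, from compound 1 to compound 2, removed one chlorine from the same ring and stayed within the scatter, so adding two chlorines is expected to give at most a modest rise, a 1.7-fold higher number from compound 2 to compound 3 (0.23 log units; within the scatter). The estimate for compound 3 is therefore 1000000000 nM, between 450000000 nM and 2500000000 nM.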

Compound 3, half-maximal inhibitory concentration: 269000000 nM
The estimate for compound 3 lay 3.7-fold (0.57 log units) above the measured number; the whole stated range lies above it.
By their numbers in this assay, from the lowest: compound 3; then compounds 2 and 1 (each within the scatter of the next).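

In this assay, for the compounds shown here, the single chlorine of compound 1 left no readable change, yet the 2,4-dichlorophenyl group does move the number, giving a 2.2-fold lower number from compound 2 to compound 3 (0.34 log units; beyond the scatter) and a 3.2-fold lower number from compound 1 to compound 3 (0.50 log units; beyond the scatter) as well. Chlorines on this ring are therefore accepted here, and compound 3 is the strongest of the three, though only the two-chlorine ring shows this. No available data explain the drop. From the compounds shown here alone, whether it is specific to chlorine stays open, as a methoxy group or an amine on this ring could behave differently.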